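Chromene chalcones: from a nitro to a bromo-hydroxy aryl

The source may report more compounds than this note shows. Statements on the series, on what has been measured and on what is new or still open speak of the compounds shown alone.

The measured compounds:
compound 1 `CCN(CC)c1ccc(/C=C/C(=O)c2ccc(OC)c3c2OC(C)(C)C=C3)cc1` gives 610 nM in a functional assay on SK-OV-3 cells (Homo sapiens) for antiproliferative activity, read by MTT assay, with a stated time of 24 h; on this read-out higher numbers stand for weaker inhibition and lower numbers for stronger inhibition;
compound 2 `COc1ccc(C(=O)/C=C/c2ccc(N(c3ccccc3)c3ccccc3)cc2)c2c1C=CC(C)(C)O2` reaches only a limit of this assay, > 10000 nM;
compound 3 `COc1ccc(C(=O)/C=C/c2ccc([N+](=O)[O-])cc2)c2c1C=CC(C)(C)O2` gives 3420 nM in this assay.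

Compound 3 holds the highest of the two numbers in this assay; its nearest neighbour is compound 1, with a 5.6-fold higher number from compound 1 to compound 3 (0.75 log units; beyond the scatter). The third value shown, for compound 2, is a limit and no number, as stated in the limit of > 10000 nM in this assay, at which 1 of the 3 values shown sits.

Compound 4 `COc1ccc(C(=O)/C=C/c2ccc(O)c(Br)c2)c2c1C=CC(C)(C)O2` differs from compound 3 in one place: 3-bromo-4-hydroxyphenyl in place of 4-nitrophenyl on a double-bonded chain carbon bound to a double-bonded chain carbon. Among the measured compounds shown here, only one measured step is available in this assay, the step from compound 1 to compound 3, and it concerns a nitro replacing a diethylamino, not a hydroxyl or a bromine. It therefore bears on the new step only in showing that the aryl end of the chain can move the read-out by a modest amount. The expectation for compound 4 in this assay is a step of a 1.1-fold lower number from compound 3 to compound 4 (0.06 log units; within the scatter), that is, no change beyond the scatter. On that basis compound 4 is estimated at 3000 nM, with a range from 800 nM to 12000 nM.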

Compound 4, half-maximal inhibitory concentration: > 10000 nM
Compound 4 ended at the assay's limit; the forecaster's own chance of this, stated with the estimate: 20%; middle value at least 3.3-fold (0.52 log units) away from the limit.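

In this assay, 3-bromo-4-hydroxyphenyl in place of 4-nitrophenyl on a double-bonded chain carbon bound to a double-bonded chain carbon gives an at least 2.9-fold higher number from compound 3 to compound 4 (0.46 log units; beyond the scatter), so a second change at this position moves the read-out beyond the scatter, in the same direction as a 5.6-fold higher number from compound 1 to compound 3 (0.75 log units; beyond the scatter). Compound 4 stands at > 10000 nM, which is a limit of the assay and not a number, so the step has a lower bound but no known size. The earlier compounds showed the limit only for the diphenylamino end of compound 2, whereas it is now also reached by an aryl end that carries a hydroxyl and a bromine: the limit of > 10000 nM in this assay, at which 2 of the 4 values shown sit.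

The hydroxyl and the bromine enter together in compound 4, so the compounds shown do not tell which of them goes with the step. On these data alone, how the aryl end would read in this assay with the hydroxyl alone, with the bromine alone, or with a methoxy or a primary amine in place of the hydroxyl remains open.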